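The source may hold more compounds than are shown below. What is called first, only, known or untested is meant among the compounds shown, and "the series" means these compounds.

Compound 1 `CCCn1c(=O)[nH]c2nc(-c3ccc(S(=O)(=O)N4CCN(c5ccc(Br)cc5)CC4)cc3)[nH]c2c1=O` and compound 2 `CCCn1c(=O)[nH]c2nc(-c3ccc(S(=O)(=O)N4CCN(c5ccccc5C)CC4)cc3)[nH]c2c1=O` share one core and differ only in the group on the ring amine nitrogen. In an assay on CHO cells for displacement of a labelled ligand from adenosine receptor A3 (Homo sapiens), read by scintillation counting, with a stated time of 45 min, in the presence of a further agent that is not named here (on this read-out lower numbers stand for stronger inhibition and higher numbers for weaker inhibition), compound 1 returns a limit, > 1000 nM. In this assay compound 2 likewise returns a limit, > 1000 nM. The step that the two limits leave unreadable from compound 1 to compound 2 cannot be read because of the limit of > 1000 nM in this assay, at which 2 of the 2 values shown sit. Compound 2 thus stands at the limit of this assay, with no number of its own among the values shown.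

Compound 3 `CCCn1c(=O)[nH]c2nc(-c3ccc(S(=O)(=O)N4CCN(Cc5cccc(Br)c5)CC4)cc3)[nH]c2c1=O` differs from compound 2 in one place: 3-bromobenzyl in place of 2-methylphenyl on an amine nitrogen in a ring. Among the compounds with values here, the only measured step, a step that the two limits leave unreadable from compound 1 to compound 2, concerns the same ring nitrogen but sets neither size nor direction, so no step beyond the scatter can be argued in either sense in this assay. Compound 3 is expected to stay near the limit, the step that the limit leaves unreadable from compound 2 to compound 3 being an estimate only. The estimated value for compound 3 in this assay is 3000 nM, within a range from 700 nM to 20000 nM.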

Compound 3, inhibition constant: > 1000 nM
Compound 3: only a limit was reported; the forecaster's own chance of this, stated with the estimate: 70%; the middle value lies beyond the limit too.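

Within the data shown here, no step among compound 1, compound 2 and compound 3 can be read, each value being a limit and not a number: the limit of > 1000 nM in this assay, at which 3 of the 3 values shown sit. The compounds shown leave open where each of the three truly sits, and whether the group on the ring amine nitrogen shifts binding at all.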